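Replacing cyano with 1,3-benzothiazol-2-yl

The source may hold more compounds than are shown below. What is called first, only, known or untested is meant among the compounds shown, and "the series" means these compounds.

Measured in a functional assay for inhibition, with Homo sapiens as the target; a lower number here means a stronger inhibitor, a higher number a weaker inhibitor:
- compound 1 `N#Cc1cc(-c2ccccc2)c2ccc(OCc3cccc(C4(O)CCOCC4)c3)cc2c1`: 3 nM
- compound 2 `OC1(c2cccc(COc3ccc4c(-c5ccccc5)cc(-c5nn[nH]n5)cc4c3)c2)CCOCC1`: > 700 nM, a limit of the assay
- compound 3 `N#Cc1cc(-c2ccoc2)c2ccc(OCc3cccc(C4(O)CCOCC4)c3)cc2c1`: 2 nM

Compound 3 stands level with compound 1, and the furan-3-yl swap gives a 1.5-fold lower number from compound 1 to compound 3 (0.18 log units; within the scatter). The next structure is compound 4 `OC1(c2cccc(COc3ccc4c(-c5ccoc5)cc(-c5nc6ccccc6s5)cc4c3)c2)CCOCC1`, where 1,3-benzothiazol-2-yl takes the place of cyano: 1,3-benzothiazol-2-yl in place of cyano on an aromatic carbon. Going by the values given here, only one measured change touches this place, 2H-tetrazol-5-yl in place of cyano, and it gave an at least 230-fold higher number from compound 1 to compound 2 (2.36 log units; beyond the scatter). That warns of a possible loss, but the entering group is a different one, so a smaller rise in this assay is expected. The estimated change is a 10-fold higher number from compound 3 to compound 4 (1.00 log units; beyond the scatter). For compound 4 the estimate is 20 nM, with an expected range from 2 nM to 200 nM.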

Compound 4, half-maximal inhibitory concentration: > 62 nM
Compound 4: only a limit was reported; the forecaster's own chance of this, stated with the estimate: 10%; middle value at least 3.1-fold (0.49 log units) from the limit.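

Compound 4 is reported only as a limit: the limit of > 62 nM in this assay, at which 1 of the 4 values shown sits. Even so, the step reads an at least 31-fold higher number from compound 3 to compound 4 (1.49 log units; beyond the scatter) and shows that in this assay a second, quite different group in place of cyano also gives a much weaker inhibitor, this time with furan-3-yl on the core rather than phenyl. So the loss is not confined to 2H-tetrazol-5-yl, and among the compounds shown only compound 1 and compound 3, which keep cyano, stay low.

On these data alone, whether a chloro group or a primary amide at this place would hold the low number stays open. Compound 2 and compound 4 both end in limits, so the two replacements cannot be ranked.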